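Adding a methyl at a chain carbon: effect on tolerance

This account rests on a few compounds, and the source may have more. Where it says the series, first, only, none or still open, it means among the compounds named here.

Compound 1 `Cc1ccc2cc(CN(Cc3ccc(C(C)(C)C)cc3)C3CCCC3)c(=O)[nH]c2c1` and compound 2 `CCc1ccc2cc(CN(Cc3ccc(C(C)(C)C)cc3)C3CCCC3)c(=O)[nH]c2c1` were both tested in a toxicity assay on MDCK cells (Canis lupus familiaris) for cytotoxicity, read by crystal violet staining, with a stated time of 48 h; a higher number here means that more compound is tolerated, a lower number that less compound is tolerated. Compound 1 gives > 10000 nM, which is a limit of the assay rather than a number. Compound 2 gives > 9000 nM, again only a limit of the assay. The change between them is methyl in place of hydrogen on a saturated chain carbon bound to an aromatic carbon, and the two limits leave a step that the two limits leave unreadable from compound 1 to compound 2. Compound 3 `COc1ccc(C(C)N(Cc2ccc(C(C)(C)C)cc2)Cc2cc3cc(C)ccc3[nH]c2=O)cc1` gives > 5000 nM in this assay, also a limit. The difference between the cores of compound 1 and compound 3 is not broken down here. Compound 4 `CCc1ccc2[nH]c(=O)c(CN(Cc3ccc(C(C)(C)C)cc3)C(C)c3ccc(OC)cc3)cc2c1` has not been measured; it differs from compound 3 by methyl in place of hydrogen on a saturated chain carbon bound to an aromatic carbon, the same change as from compound 1 to compound 2. For compound 4 the step is expected to be a step that the limit leaves unreadable from compound 3 to compound 4, which rests on a step that the two limits leave unreadable from compound 1 to compound 2. Compound 4 is therefore expected to give around 10000 nM in this assay, most probably again reported only as a limit.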

Compound 4, half-maximal cytotoxic concentration: > 5000 nM
Compound 4 ended at the assay's limit; the forecaster's own chance of this, stated with the estimate: 85%; the middle value is on the limit's open side.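

Among these compounds, the results for compound 3 and compound 4 are both limits, and the step between them cannot be read, any more than the one between compound 1 and compound 2. The compounds shown leave open whether the change from methyl to ethyl alters tolerance at all.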